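This account rests on a few compounds, and the source may have more. Where it says the series, first, only, none or still open, it means among the compounds named here.

Series notes. Compound 1 `C=Cc1cccc(-c2[nH]c3cc(OC)ccc3c(=O)c2C(=O)OCC)c1`, compound 2 `CCCOc1cccc(-c2[nH]c3cc(OC)ccc3c(=O)c2C(=O)OCC)c1` and compound 3 `CCOC(=O)c1c(-c2cccc(OCc3ccccc3)c2)[nH]c2cc(OC)ccc2c1=O` share one core and differ only in the group carried on the pendant aromatic ring. In an ADME assay on BJ cells (Homo sapiens) for cytotoxicity, read by luminescence, with a stated time of 72 h (a higher number here means that more compound is needed for the effect, a lower number that less compound is needed), compound 1 gives > 21500 nM, which is a limit of the assay and not a number. Compound 2 gives > 21500 nM in this assay, again a limit. Compound 3 gives > 21500 nM in this assay, also a limit. Compound 2 therefore stands at the limit of > 21500 nM in this assay, at which 3 of the 3 values shown sit, and no number separates it from either neighbour. Compound 4 `CCOC(=O)c1c(-c2cccc([N+](=O)[O-])c2)[nH]c2cc(OC)ccc2c1=O` is not yet measured; it differs from compound 2 by nitro in place of propoxy on an aromatic carbon. The measured steps that touch the same position are a step that the two limits leave unreadable from compound 1 to compound 2 and a step that the two limits leave unreadable from compound 2 to compound 3, and a third, a step that the two limits leave unreadable from compound 1 to compound 3, is no more readable; every step in this assay starts and ends at a limit, so no size and no direction can be taken from them. Compound 4 is expected to give 30000 nM, between 15000 nM and 80000 nM, most probably reported once more as a limit. The step this estimate means is a step that the limit leaves unreadable from compound 2 to compound 4, expected to stay within the scatter.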

Compound 4, half-maximal effective concentration: > 21500 nM
Compound 4 gave a limit, no number (the forecaster's own chance of this, stated with the estimate: 85%); the middle value is on the limit's open side.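

Compound 4 joins compound 1, compound 2 and compound 3 at a limit in this assay and not at a number, so no new step can be read from any of them: the limit of > 21500 nM in this assay, at which 4 of the 4 values shown sit.

The compounds shown leave open at what concentration any of them takes effect in this assay and whether vinyl, propoxy, benzyloxy and nitro differ there at all.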